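Dichlorines on a Diacylhydrazide Sulfonamide

The source may report more compounds than this note shows. Statements on the series, on what has been measured and on what is new or still open speak of the compounds shown alone.

Compound 1 `NS(=O)(=O)c1ccc(C(=O)NNC(=O)c2ccccc2)cc1` is a benzenesulfonamide joined through a diacylhydrazide bridge to a plain phenyl group. In an assay on cells for inhibition of Amine oxidase [flavin-containing] B (Homo sapiens), read by fluorescence and spectrophotometry, using microsomes, with a stated time of 20 min (on this read-out higher numbers stand for weaker inhibition and lower numbers for stronger inhibition), compound 1 is reported only as a limit, > 100000 nM, so its true potency is not known beyond that. This is the limit at which (the limit of > 100000 nM in this assay, at which 1 of the 3 values shown sits). Two further compounds with the sulfonamide but a different bridge have numbers: compound 2 `N#Cc1ccc(-c2nnc(-c3ccc(S(N)(=O)=O)cc3)o2)cc1` gives 318 nM in this assay, and compound 3 `NS(=O)(=O)c1cccc(-c2nnc(-c3ccc(F)cc3)o2)c1` gives 975 nM in this assay.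

Compound 4 `NS(=O)(=O)c1ccc(C(=O)NNC(=O)c2ccc(Cl)c(Cl)c2)cc1` keeps the whole core of compound 1 and changes one ring: 3,4-dichlorophenyl in place of phenyl on a carbonyl carbon. Among the compounds with values here, no pair of measured compounds shows this change, so its effect is not known. Because compound 1 sits at the limit > 100000 nM, the expected step from compound 1 to compound 4 is a number no higher from compound 1 to compound 4 (the limit leaves the size open), a change that may not reach beyond the scatter. Compound 4 is therefore estimated at 100000 nM, within a range from 20000 nM to 300000 nM.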

Compound 4, half-maximal inhibitory concentration: 10100 nM
Compound 4: middle estimate off by 9.9-fold (1.00 log units), on the high side; measured number below the stated range.
By their numbers in this assay, from the lowest: compound 2; then compound 3; then compound 4. At a limit, above all of these: compound 1.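

On a carbonyl carbon, 3,4-dichlorophenyl in place of phenyl gives an at least 9.9-fold lower number from compound 1 to compound 4 (0.99 log units; beyond the scatter), so the diacylhydrazide series responds to a change at this ring. Within the data shown here, the earlier compounds offered no pair differing in one place, which makes this the first change in this assay that can be read on its own. The full size of the step stays unknown because compound 1 is held only as a limit: the limit of > 100000 nM in this assay, at which 1 of the 4 values shown sits.

Going by these compounds, what a single chlorine on this ring would do remains open, as does the effect of an amine or a carboxylic acid there. It is also unknown whether the same change would lower the number for compound 2 and compound 3, which carry a different bridge.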